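The source may report more compounds than this note shows. Statements on the series, on what has been measured and on what is new or still open speak of the compounds shown alone.

Compound 1, `COc1ccc2[nH]c(C(=O)N3CC(=O)N(Cc4ccccc4)[C@@H](CN4CCC5(CC4)CC5)C3)cc2c1`: 28200 nM
Compound 2, `COc1ccc2[nH]c(C(=O)N3CC(=O)N(Cc4cccc(OC(F)F)c4)[C@@H](CN4CC5CCC4C5)C3)cc2c1`: 62000 nM

In a physicochemical assay for solubility, read by spectrophotometry, in phosphate buffer, with a stated time of 2 h, at pH 7.4 (a lower number here means a less soluble compound, a higher number a more soluble compound), compound 1 gives 28200 nM, the lowest of the two numbers; the nearest number is that of compound 2, which gives 62000 nM in this assay, and the gap between the two lies beyond the scatter. Compound 3, `COc1ccc2[nH]c(C(=O)N3CC(=O)N(Cc4ccccc4)[C@@H](CN4CC5(CCC5)C4)C3)cc2c1`, differs from compound 1 by a group of 7 heavy atoms (6 carbon, 1 nitrogen; one four-membered non-aromatic ring of carbon only, one four-membered non-aromatic ring with 1 hetero atom) in place of a group of 8 heavy atoms (7 carbon, 1 nitrogen; one three-membered non-aromatic ring of carbon only, one six-membered non-aromatic ring with 1 hetero atom), on a saturated chain carbon bound to a saturated ring carbon. Among the compounds with values here, no pair of measured compounds shares this change, so nothing measured shows its size directly. Compound 3 is expected to show a small upward step, a 1.4-fold higher number from compound 1 to compound 3 (0.15 log units; within the scatter), one that may well sit within the scatter of this assay. Compound 3 is therefore estimated at 40000 nM in this assay, with a range from 15000 nM to 100000 nM, its value in this assay still to be measured.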

Compound 3, solubility: 60700 nM
The estimate for compound 3 lay 1.5-fold (0.18 log units) below the measured number, within the range that was stated.
By their numbers in this assay, from the lowest: compound 1; then compounds 3 and 2 (each within the scatter of the next).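

Within the data shown here, compound 1 and compound 3 give the first comparison that isolates this position, the saturated chain carbon bound to a saturated ring carbon, with the rest of the structure held constant. In this assay, the group with one four-membered non-aromatic ring of carbon only and one four-membered non-aromatic ring with 1 hetero atom, in place of the group with one three-membered non-aromatic ring of carbon only and one six-membered non-aromatic ring with 1 hetero atom, gives a 2.2-fold higher number from compound 1 to compound 3 (0.33 log units; beyond the scatter), so this exchange alone moves the number by a modest step. Nothing at hand accounts for that step.

This single pair does not show whether the step would hold with a substituent on the other parts of the structure. As far as these compounds go, how a morpholine, a piperidine or a dimethylamino group would read at this position also remains open.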